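The source may report more compounds than this note shows. Statements on the series, on what has been measured and on what is new or still open speak of the compounds shown alone.

Compound 1 `CS(=O)(=O)N1CCN(S(=O)(=O)CCCN2CCC(CNC(=O)c3cccc4c3OCCO4)CC2)CC1` and compound 2 `O=C(NCC1CCN(CCCS(=O)(=O)N2CCOCC2)CC1)c1cccc2c1OCCO2` share one core and differ only in the ring attached to a sulfonyl sulfur. In an assay on isolated protein for inhibition of 5-hydroxytryptamine receptor 4 (Homo sapiens) (a lower number here means a stronger inhibitor, a higher number a weaker inhibitor), compound 1 gives 0.316 nM. In this assay compound 2 gives 0.398 nM. The step of a 1.3-fold higher number from compound 1 to compound 2 (0.10 log units; within the scatter) lay within the scatter, so exchanging the ring on that sulfur made no difference that the assay could resolve. For the measured compounds named here, of the two numbers so far, compound 2 has the higher one, but its only neighbour, compound 1, sits within the scatter of it, and the two cannot be told apart.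

Compound 3 `O=C(NCC1CCN(CCCS(=O)(=O)N2CCN(C3CCCC3)CC2)CC1)c1cccc2c1OCCO2` keeps the shared core and changes the same place once more: 4-cyclopentylpiperazin-1-yl in place of morpholin-4-yl on a sulfonyl sulfur. Going by the values given here, the incoming group is larger, yet the only step that bears on this place, a 1.3-fold higher number from compound 1 to compound 2 (0.10 log units; within the scatter), was within the scatter, and no measured pair shows what a cyclopentyl group does here. A step of no real size in this assay is therefore expected, a 1.1-fold lower number from compound 2 to compound 3 (0.06 log units; within the scatter). Compound 3 is expected to give 0.35 nM, somewhere between 0.12 nM and 1.1 nM.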

Compound 3, inhibition constant: 0.0159 nM
Estimate against measurement, compound 3: 22-fold (1.34 log units) above, and the stated range ends above it.
By their numbers in this assay, from the lowest: compound 3; then compounds 1 and 2 (each within the scatter of the next).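

The ring on the sulfonyl sulfur is not a silent position in this assay, as the earlier pair suggested: the step of a 25-fold lower number from compound 2 to compound 3 (1.40 log units; beyond the scatter) and the step of a 20-fold lower number from compound 1 to compound 3 (1.30 log units; beyond the scatter) are both large and beyond the scatter. Compound 3 therefore stands alone as the strongest inhibitor of the three, and 4-cyclopentylpiperazin-1-yl is the only group shown on that sulfur that separates itself from the others. The comparison of compound 1 with compound 3 is the narrower one, since the piperazin-1-yl part stays and only the group on its amine nitrogen changes, with cyclopentyl in place of methylsulfonyl. No measured property is at hand that would account for this drop in the number.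

As far as these compounds go, what stays open is whether this drop belongs to the cyclopentyl group itself or would also appear with other carbon groups on that amine nitrogen, such as methyl, isopropyl or cyclohexyl. A plain hydrogen on that nitrogen would show how much of the drop needs any carbon group there at all.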